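The compounds below may be only part of what the source reports. "The series", "measured", "known", "first", "only" and "open" are said of these compounds alone.

Measured so far in an ADME assay on Vero cells (Chlorocebus sabaeus) for cytotoxicity, with a stated time of 5 days; a lower number here means a stronger inhibitor, a higher number a weaker inhibitor:
compound 1 `CC(C)(CO)Nc1nc(N)nc2c1ncn2[C@H]1C[C@H](N=[N+]=[N-])[C@@H](CO)O1`: > 100000 nM
compound 2 `CN(C)c1nc(N)nc2c1ncn2[C@H]1C[C@H](N=[N+]=[N-])[C@@H](CO)O1`: > 100000 nM
compound 3 `CN(C)c1nc(Cl)nc2c1ncn2[C@H]1C[C@H](N=[N+]=[N-])[C@@H](CO)O1`: > 100000 nM

All three entries are limits of the assay, not numbers. Compound 2 has only the limit > 100000 nM, so it cannot be ranked against the other two compounds. The picture is summed up by the limit of > 100000 nM in this assay, at which 3 of the 3 values shown sit.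

Compound 4 `C#CCNc1nc(N)nc2c1ncn2[C@H]1C[C@H](N=[N+]=[N-])[C@@H](CO)O1` carries propargylamino in place of dimethylamino on an aromatic carbon. The closest measured change is at the same place: a step that the two limits leave unreadable from compound 1 to compound 2, with dimethylamino in place of (1-(hydroxymethyl)-1-methylethyl)amino. The other measured change, a step that the two limits leave unreadable from compound 2 to compound 3, has chloro in place of amino, so it concerns a different group. Neither step has a readable size, so neither gives a measured effect to carry over.

Within the data shown here, the expectation rests on the three limits alone, as the limit of > 100000 nM in this assay, at which 3 of the 3 values shown sit, shows no compound giving a number in this assay. Compound 4 is most likely expected to report only a limit as well, with no readable change from compound 2. If a number does appear, it is expected near the limit, on the stronger side. The estimated step is a number no higher from compound 2 to compound 4 (the limit leaves the size open). For compound 4 the estimated value is 100000 nM, with an expected range of 50000 nM to 200000 nM.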

Compound 4, half-maximal inhibitory concentration: > 100000 nM
Compound 4 ended at the assay's limit; the forecaster's own chance of this, stated with the estimate: 80%; the middle value sits exactly at the limit.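

In this assay compound 4 gives > 100000 nM, a limit of the assay and not a number, so the steps to compound 4 from compound 1 and compound 2 cannot be read. The compounds shown leave open whether any of these changes shifts the read-out in this assay, with no compound yet giving a number: the limit of > 100000 nM in this assay, at which 4 of the 4 values shown sit.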